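Swapping the aryl group on the sulfonyl of compound 1

The source may hold more compounds than are shown below. What is called first, only, known or untested is meant among the compounds shown, and "the series" means these compounds.

Compound 1 `N#Cc1ccc(O[C@H]2CN(S(=O)(=O)c3ccc(Cl)cc3)C[C@@]2(O)CO)cc1F` is the best of three measured compounds in an ADME assay on the whole organism (Rattus norvegicus, strain Sprague-Dawley) for pharmacokinetics, read by LC-MS (on this read-out higher numbers stand for higher oral bioavailability and lower numbers for lower oral bioavailability), where compound 1 gives 83%. Compound 2 `N#Cc1ccc(O[C@H]2CN(S(=O)(=O)c3ccc(Cl)cn3)C[C@@]2(O)CN)cc1F` gives 26% in this assay, and compound 3 `N#Cc1ccc(O[C@H]2CN(S(=O)(=O)c3ccc(Cl)cc3Cl)C[C@@]2(O)CN)cc1F` gives 24%; both numbers lie far below that of compound 1, beyond the scatter. Compounds 2 and 3 differ from compound 1 in two places, so their gaps to compound 1 cannot be traced to a single change.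

Compound 4 `N#Cc1ccc(O[C@H]2CN(S(=O)(=O)c3ccccc3C#N)C[C@@]2(O)CO)cc1F` differs from compound 1 in one place: 2-cyanophenyl in place of 4-chlorophenyl on a sulfonyl sulfur. Among the compounds with values here, the only measured step that touches the group on the sulfonyl sulfur is a number 2 percentage points lower from compound 2 to compound 3 (within the scatter), a swap of that aryl group that left the number essentially unchanged. On that basis the swap to 2-cyanophenyl is expected to bring no step beyond the scatter, with an expected step of a number 11 percentage points lower from compound 1 to compound 4 (beyond the scatter). Compound 4 is therefore estimated at 72%, within a range from 45% to 92%.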

Compound 4, oral bioavailability in the Rattus norvegicus assay: 32%
Compound 4: middle estimate off by 40 percentage points, on the high side; measured number below the stated range.
By their numbers in the Rattus norvegicus assay, from the lowest: compounds 3, 2 and 4 (each within the scatter of the next); then compound 1.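

On the sulfonyl sulfur, the aryl group can matter a great deal in the Rattus norvegicus assay: unlike the earlier swap between compounds 2 and 3, which stayed within the scatter, this change gives a number 51 percentage points lower from compound 1 to compound 4 (beyond the scatter). In a physicochemical assay for lipophilicity, at pH 7.4 (a lower number here means a more polar compound, a higher number a more lipophilic compound), compound 1 gives 4.1 and compound 4 gives 3.4. The swap therefore also lowers lipophilicity, a measured change that runs alongside the loss of oral bioavailability, although a single pair cannot show that it is the cause: the measured distribution coefficient of compound 1, 4.1, and of compound 4, 3.4, a number 0.70 log units lower (beyond the scatter)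

The chlorine left and the nitrile entered in one change, so the compounds shown cannot tell which of the two accounts for the drop. Nor do they show how an aryl group carrying a methoxy or a trifluoromethyl group on this sulfur would behave.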